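Swapping the Amide Arm of Compound 3 for a Carbamoyl Arm

The source may report more compounds than this note shows. Statements on the series, on what has been measured and on what is new or still open speak of the compounds shown alone.

The measured compounds are:
compound 1, `O=C(Nc1cccc(-n2cc(-c3ccncc3)c(-c3ccc(Cl)c(O)c3)n2)c1)Nc1cccc(C(F)(F)F)c1`, 1340 nM;
compound 2, `COc1cc(-c2nn(-c3cccc(NC(=O)Nc4cc(C(F)(F)F)cc(C(F)(F)F)c4)c3)cc2-c2ccncc2)ccc1Cl`, 310 nM;
compound 3, `COc1cc(-c2nn(-c3cccc(NC(=O)c4cccc(C(F)(F)F)c4)c3)cc2-c2ccncc2)ccc1Cl`, 1570 nM.

These three were tested in a functional assay on RPMI-8226 cells (Homo sapiens) for inhibition, read by sulforhodamine B assay, with a stated time of 48 h; on this read-out higher numbers stand for weaker inhibition and lower numbers for stronger inhibition. Compound 3 gives the highest of the three numbers. Its nearest neighbour is compound 1, whose number lies within the usual scatter of that of compound 3, so the two cannot be told apart. Compound 2 stands well apart from compound 3, its number being beyond the scatter in the lower direction.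

Compound 4, `COc1cc(-c2nn(-c3cccc(NC(=O)Nc4ccc(Cl)c(Cl)c4)c3)cc2-c2ccncc2)ccc1Cl`, has not yet been measured. It differs from compound 3 in one place: (3,4-dichlorophenyl)amino in place of 3-(trifluoromethyl)phenyl on a carbonyl carbon.

Within the data shown here, no measured pair shows this exact change, so the expected step rests on the three values alone. The step from compound 3 to compound 4 is estimated as a 3.1-fold lower number from compound 3 to compound 4 (0.50 log units; beyond the scatter), a fall in the number, because compound 2 carries a carbamoyl arm on the same core and gives 310 nM. The expected value for compound 4 is 500 nM, with a range from 150 nM to 1600 nM.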

Compound 4, half-maximal inhibitory concentration: 390 nM
The estimate for compound 4 lay 1.3-fold (0.11 log units) above the measured number, and the stated range covers the measured number.
By their numbers in this assay, from the lowest: compounds 2 and 4 (each within the scatter of the next); then compounds 1 and 3 (each within the scatter of the next).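

Replacing 3-(trifluoromethyl)phenyl with (3,4-dichlorophenyl)amino on a carbonyl carbon gives a 4.0-fold lower number from compound 3 to compound 4 (0.60 log units; beyond the scatter) in this assay, so this position responds to the change by more than the scatter. The entering group brings both a new amide-type nitrogen, with a hydrogen-bond donor that the leaving group lacks, and a different ring substitution, and this single step does not separate the two. Compound 4, at 390 nM, lies within the scatter of compound 2, at 310 nM, so these two carbamoyl arms cannot be told apart here.

The compounds shown leave open whether the nitrogen or the two chlorines account for the step, and how a sulfonamide link in place of the carbonyl would read. Nothing measured here bears on why the number fell.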